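Cytotoxicity notes: from compound 3 to compound 4

The source may report more compounds than this note shows. Statements on the series, on what has been measured and on what is new or still open speak of the compounds shown alone.

Measured so far in an ADME assay on HepG2 2.2.15 cells (Homo sapiens) for cytotoxicity; a higher number here means that more compound is tolerated, a lower number that less compound is tolerated:
- compound 1, `O=C(Nc1ncc(Cc2ccc(F)cc2)s1)c1ccc(Cl)cc1Cl`: > 50000 nM.
- compound 2, `COCCc1ccc(OC(c2ccc(Cl)cc2)c2cnc(NC(=O)OC(C)(C)C)s2)cc1`: > 50000 nM.
- compound 3, `Clc1ccc(C(Oc2ccc3cc(Br)ccc3c2)c2cnc(NCC3CCCCC3)s2)cc1`: compound 3 gives "not toxic" (no number reported).

For compound 1 the value > 50000 nM is a limit of this assay and not a number. For compound 2 the value > 50000 nM is likewise a limit. Compound 3 has no single number in this assay; it is reported only as "not toxic" (no number reported), while the two other values shown sit at the limit of > 50000 nM in this assay, at which 2 of the 3 values shown sit. Among the measured compounds shown here, no pair of measured compounds differs in one place, so no step within the measured set can be read.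

Compound 4, `O=C(Nc1ncc(C(Oc2ccc3cc(Br)ccc3c2)c2ccc(Cl)cc2)s1)c1ccc(F)cc1F`, is the next compound to be measured. It differs from compound 3 by (2,4-difluorophenyl)carbonyl in place of cyclohexylmethyl on a nitrogen on an aromatic ring.

In this assay no step beyond the usual scatter is expected from compound 3 to compound 4, in either direction. Compound 4 is expected to give about 50000 nM, with a range from 20000 nM to 100000 nM, and most likely the assay will again report only a limit.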

Compound 4, half-maximal cytotoxic concentration: "not toxic" (no number reported)
Compound 4 has no reported number here; no gap can be computed for the estimate.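

In this assay, among the compounds shown here, compound 3 and compound 4 are both reported only as "not toxic", with no number, so no step between them can be read. The compounds shown leave open whether replacing cyclohexylmethyl with (2,4-difluorophenyl)carbonyl changes how much compound the cells tolerate.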